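The compounds below may be only part of what the source reports. "The series", "measured", "known", "first", "only" and "open" are said of these compounds alone.

Compound 1 `CC(C)COc1cccc2occ(Cc3coc4ccccc4c3=O)c(=O)c12` — in a functional assay on NCI-H23 cells (Homo sapiens) for antiproliferative activity, read by XTT assay (on this read-out lower numbers stand for stronger inhibition and higher numbers for weaker inhibition), compound 1 gives > 10000 nM, a limit of the assay.
Compound 2 `O=c1c(Cc2coc3cccc(OCc4ccccc4)c3c2=O)coc2ccccc12` — in this assay compound 2 gives > 10000 nM, likewise a limit.

Compound 2 therefore stands only at a limit, with no number of its own; both values shown sit at that same limit (the limit of > 10000 nM in this assay, at which 2 of the 2 values shown sit). The step that the two limits leave unreadable from compound 1 to compound 2 cannot be read. Compound 3 `COc1cccc2occ(Cc3coc4ccccc4c3=O)c(=O)c12` differs from compound 2 by hydrogen in place of phenyl on a saturated chain carbon bound to an oxygen on an aromatic ring. Among the measured compounds shown here, the only measured step touching this position is the unreadable one from compound 1 to compound 2, so no size or direction can be taken from it. Compound 3 is expected at 15000 nM, range 5000 nM to 50000 nM. The estimated step that the limit leaves unreadable from compound 2 to compound 3 is thus expected to stay within the scatter.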

Compound 3, half-maximal inhibitory concentration: 1930 nM
Estimate against measurement, compound 3: 7.8-fold (0.89 log units) above; measured number outside the range, below it.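

Among the compounds shown here, at this position, methoxy is the first group to give a readable number in this assay: benzyloxy to methoxy gives an at least 5.1-fold lower number from compound 2 to compound 3 (0.71 log units; beyond the scatter), and hydrogen in place of isopropyl on the same chain carbon gives an at least 5.1-fold lower number from compound 1 to compound 3 (0.71 log units; beyond the scatter). Both larger groups thus lose to methoxy by a margin beyond the scatter, though neither step has a fixed size and the step between the two larger groups cannot be read: the limit of > 10000 nM in this assay, at which 2 of the 3 values shown sit.

Going by these compounds, whether an ethoxy group or a free hydroxyl at this place would move the number further remains open. So does the effect of a chain ending in an amine or a carboxylic acid.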